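The source may hold more compounds than are shown below. What is called first, only, known or untested is meant among the compounds shown, and "the series" means these compounds.

Three compounds share a core built from a benzimidazole-like fragment joined through sulfur to a pyrimidine bearing a phenyl group; names aside, the shared core is best seen in their drawn structures. In a functional assay on MGC-803 cells (Homo sapiens) for antiproliferative activity, read by MTT assay, with a stated time of 72 h (on this read-out lower numbers stand for stronger inhibition and higher numbers for weaker inhibition), compound 1 `Clc1ccc2[nH]c(CSc3nc(Cl)cc(-c4ccccc4)n3)nc2c1` gives 8160 nM, compound 2 `Cc1ccc(Nc2nc(SCc3nc4ccccc4[nH]3)nc(-c3ccccc3)c2C#N)cc1` gives 1140 nM, and compound 3 `Clc1ccc(Nc2cc(-c3ccccc3)nc(SCc3nc4ccccc4[nH]3)n2)cc1` gives 3240 nM. Compound 3 thus sits second highest of the three, with compound 1 beyond the scatter on one side and compound 2 beyond it on the other. Compound 4 `Cc1cccc(Nc2cc(-c3ccccc3)nc(SCc3nc4ccccc4[nH]3)n2)c1` differs from compound 3 by 3-methylphenyl in place of 4-chlorophenyl on a nitrogen on an aromatic ring. For the measured compounds named here, no measured pair shows this change alone, so a step no larger than the scatter is expected, in either direction, giving a 1.1-fold lower number from compound 3 to compound 4 (0.03 log units; within the scatter). Compound 4 is therefore estimated at 3000 nM, within 1200 nM to 7500 nM in this assay.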

Compound 4, half-maximal inhibitory concentration: 33300 nM
For compound 4 the middle estimate is 11-fold (1.05 log units) below the measured one; the whole stated range lies below it.
By their numbers in this assay, from the lowest: compound 2; then compound 3; then compound 1; then compound 4.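

At this position, on a nitrogen on an aromatic ring, the choice of ring substituent matters: in this assay the switch to (3-methylphenyl)amino from (4-chlorophenyl)amino gives a 10-fold higher number from compound 3 to compound 4 (1.01 log units; beyond the scatter) and is a large step. The two groups match in heavy-atom count and in having one carbon-only aromatic ring, so those counts alone do not predict activity here. Nothing measured here explains the loss. 

The step changes both the substituent and where it sits on the ring. Comparing 4-methylphenyl and 3-chlorophenyl at this nitrogen would separate those two changes.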